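Moving the bromo group on the aryl ether

A few compounds are considered here, and "the series" means these few. Any claim that something is new, unique, unknown or untested is made for them only; others in the source may bear on it.

In a functional assay on HepG2 cells (Homo sapiens) for antiproliferative activity, read by MTT assay, with a stated time of 72 h (on this read-out higher numbers stand for weaker inhibition and lower numbers for stronger inhibition), compound 1 `CC(C)(C)c1ccc(OCCCON2C(N)=NC(N)=NC23CCSCC3)cc1` gives 70 nM and compound 2 `NC1=NC2(CCSCC2)N(OCCCOc2ccc(Br)cc2)C(N)=N1` gives 1400 nM as the higher of the two numbers. Compound 3 `NC1=NC2(CCOCC2)N(OCCCOc2ccc(F)cc2)C(N)=N1` stands as "not determined" (no result reported) and offers no comparison. The change from compound 2 to compound 4 `NC1=NC2(CCSCC2)N(OCCCOc2cccc(Br)c2)C(N)=N1` is 3-bromophenyl in place of 4-bromophenyl on an oxygen on a saturated carbon and amounts to 3-bromophenyl in place of 4-bromophenyl on an oxygen on a saturated carbon. For the measured compounds named here, only one measured step bears on it: a 20-fold higher number from compound 1 to compound 2 (1.30 log units; beyond the scatter) with bromo in place of tert-butyl on an aromatic carbon. That step is large and beyond the scatter, so this assay can respond strongly to a swap of substituent. It exchanges one group for another and moves none, however, so it sets no direction here. Going by the values given here, no measured pair isolates the move of a bromo group. The expected result is a 1.2-fold lower number from compound 2 to compound 4 (0.07 log units; within the scatter) and is estimated to stay within the scatter, with no direction favoured. Compound 4 is expected at 1200 nM within an estimated range of 350 nM to 4000 nM on this reading.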

Compound 4, half-maximal inhibitory concentration: 90 nM
Beside the measured number, compound 4's estimate is 13-fold (1.12 log units) above it; measured number outside the range, below it.
By their numbers in this assay, from the lowest: compounds 1 and 4 (each within the scatter of the next); then compound 2.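

In this assay, moving the bromo group alone gives a 16-fold lower number from compound 2 to compound 4 (1.19 log units; beyond the scatter) with the same atoms joined differently. The earlier step exchanged one group for another, whereas this one shows that 3-bromophenyl in place of 4-bromophenyl on an oxygen on a saturated carbon is enough by itself to produce a large change, so the place of the substituent on the aryl ether matters as well as its identity. No measurement at hand explains the difference between these two bromophenyl ethers.

As far as these compounds go, whether a chloro, methoxy or tert-butyl group would respond to the same move remains open, since this comparison rests on the bromo pair alone. Also open, from the compounds shown here alone, is whether a longer chain on the oxygen would preserve the gain seen with 3-bromophenyl.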